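Replacing 4-fluorobenzyl with naphthalen-1-yl on an amide-type nitrogen

The source may report more compounds than this note shows. Statements on the series, on what has been measured and on what is new or still open speak of the compounds shown alone.

In a functional assay on HCT-116 cells (Homo sapiens) for antiproliferative activity, read by MTT assay, with a stated time of 72 h (a lower number here means a stronger inhibitor, a higher number a weaker inhibitor), compound 1 `CC(C)C[C@H](NC(=O)OCc1ccccc1)C(=O)N[C@@H](CC(C)C)C(=O)N[C@@H](CC(C)C)C(=O)C(=O)NCc1ccccc1` gives 780 nM and compound 3 `CC(C)C[C@H](NC(=O)OCc1ccccc1)C(=O)N[C@@H](CC(C)C)C(=O)N[C@@H](CC(C)C)C(=O)C(=O)NCc1ccc(F)cc1` gives 930 nM. A third relative, compound 2 `CC(C)C[C@H](NC(=O)OCc1ccccc1)C(=O)N[C@@H](CC(C)C)C(=O)C(=O)NCc1ccccc1`, gives 8600 nM, a clearly higher number than either of the others. Compound 3 therefore stands together with compound 1 at the stronger end of this small set.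

The next structure, compound 4 `CC(C)C[C@H](NC(=O)OCc1ccccc1)C(=O)N[C@@H](CC(C)C)C(=O)N[C@@H](CC(C)C)C(=O)C(=O)Nc1cccc2ccccc12`, carries naphthalen-1-yl in place of 4-fluorobenzyl on an amide-type nitrogen. Among the compounds with values here, only one measured step touches this end of the molecule. It is a 1.2-fold higher number from compound 1 to compound 3 (0.08 log units; within the scatter), made by placing fluoro in place of hydrogen on an aromatic carbon, and it stays within the scatter. That edit is far smaller than the swap of a whole group made here, so it offers only weak guidance. Within the data shown here, no measured compound carries naphthalen-1-yl, and nothing measured points firmly in either direction. A shift beyond the scatter is therefore not expected, although a surprise remains possible. The estimated change is a 1.3-fold higher number from compound 3 to compound 4 (0.11 log units; within the scatter). For compound 4 the expected value is 1200 nM, with an estimated range from 350 nM to 4500 nM.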

Compound 4, half-maximal inhibitory concentration: < 100 nM
Compound 4: no number, only a limit; the forecaster's own chance of this, stated with the estimate: 3%; at least 12-fold (1.07 log units) between middle value and limit.
By their numbers in this assay, from the lowest: compounds 1 and 3 (each within the scatter of the next); then compound 2. At a limit, below all of these: compound 4.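

The fluoro edit, with a 1.2-fold higher number from compound 1 to compound 3 (0.08 log units; within the scatter), had made this end of the molecule look unresponsive, but exchanging the whole group on the amide-type nitrogen tells a different story. Naphthalen-1-yl in place of 4-fluorobenzyl gives an at least 9.3-fold lower number from compound 3 to compound 4 (0.96 log units; beyond the scatter), and naphthalen-1-yl in place of benzyl gives an at least 7.8-fold lower number from compound 1 to compound 4 (0.89 log units; beyond the scatter), so both steps lie beyond the scatter and this position can respond strongly to the group it carries. Compound 4 has only a limit and not a number, so each of these two steps gives a minimum size: the limit of < 100 nM in this assay, at which 1 of the 4 values shown sits.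

Going by these compounds, how far compound 4 lies past that limit stays unknown, and so does the full size of the gain. The change also bundles two differences, a second aromatic ring and a ring system joined to the nitrogen in a new way, and the compounds shown cannot pull these apart, whereas phenyl or naphthalen-1-ylmethyl on the same nitrogen would be the groups to tell them apart.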